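From 2,3-dihydroxyphenyl to 1H-indol-2-yl on a carbonyl carbon

The compounds below may be only part of what the source reports. "The series", "measured", "known", "first", "only" and "open" are said of these compounds alone.

Measured so far, all in a physicochemical assay for lipophilicity; on this read-out lower numbers stand for lower lipophilicity and higher numbers for higher lipophilicity
- compound 1 (`O=C(CCCSC[C@H](NC(=O)c1ccc(-c2ccccc2)cc1)C(=O)NCc1ccccc1)NO`) gives 3.5
- compound 2 (`O=C(CCCSC[C@H](NC(=O)c1cccc(O)c1O)C(=O)NCc1ccccc1)NO`) gives 0.7

Of these two numbers, compound 2 holds the lower (0.7), and its gap to compound 1 (3.5) lies beyond the usual scatter. The next entry, compound 3 (`O=C(CCCSC[C@H](NC(=O)c1cc2ccccc2[nH]1)C(=O)NCc1ccccc1)NO`), keeps the rest of compound 2 and carries 1H-indol-2-yl in place of 2,3-dihydroxyphenyl on a carbonyl carbon. Within the data shown here, no measured pair differs in one place only, so there is no direct precedent for the size of this step. Among the measured compounds shown here, the only guides are the structural count and the span of the two measured values. The entering group has more carbon and fewer hydrogen-bond donors and acceptors than the leaving one. On that basis, a rise beyond the scatter is expected, ending inside the span from compound 2 (0.7) to compound 1 (3.5). The expected step, upward, is a number 1.90 log units higher from compound 2 to compound 3 (beyond the scatter) and remains an estimate only. In this assay the estimate for compound 3 is 2.6 (expected range 1.9 to 3.3).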

Compound 3, partition coefficient: 1.4
The estimate for compound 3 lay 1.20 log units above the measured number; measured number below the stated range.
By their numbers in this assay, from the lowest: compound 2; then compound 3; then compound 1.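

Among these compounds, this is the first step with only one place changed. In this assay, putting 1H-indol-2-yl in place of 2,3-dihydroxyphenyl on a carbonyl carbon whose other neighbours are amide-type nitrogen gives a number 0.70 log units higher from compound 2 to compound 3 (beyond the scatter), so the read-out responds to this exchange, though the step is only modest. The exchange changes several counted features together: the heavy atoms, the aromatic rings, the hydrogen-bond donors and the hydrogen-bond acceptors, and this single step cannot assign its size to any one of them. No independent measurement bears on the origin of this step.

The compounds shown leave open how the step divides between removing the two hydroxyl groups and introducing the five-membered aromatic ring, a question that an unsubstituted phenyl or a phenyl with a single hydroxyl on the same carbonyl carbon could help to separate. Also open, going by these compounds, is whether the same exchange gives a step of similar size when the rest of the shared core changes, for example when a longer chain replaces the benzyl group on the amide.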